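Methoxy for methylamino alongside a furan-2-yl substituent

The source may hold more compounds than are shown below. What is called first, only, known or untested is meant among the compounds shown, and "the series" means these compounds.

Measured compounds:
Compound 1 `CNc1ncnc2c1c(I)cn2[C@@H]1O[C@H](CO)[C@@H](O)[C@H]1O`: in a functional assay on HL-60 cells (Homo sapiens) for antiproliferative activity, read by XTT assay, with a stated time of 72 h (on this read-out lower numbers stand for stronger inhibition and higher numbers for weaker inhibition), compound 1 reaches only the assay limit of > 20000 nM.
Compound 2 `COc1ncnc2c1c(I)cn2[C@@H]1O[C@H](CO)[C@@H](O)[C@H]1O`: in this assay compound 2 gives 2300 nM.
Compound 3 `CNc1ncnc2c1c(-c1ccco1)cn2[C@@H]1O[C@H](CO)[C@@H](O)[C@H]1O`: in this assay compound 3 gives 620 nM.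

Compound 2 differs from compound 1 by methoxy in place of methylamino on an aromatic carbon, and this change produced an at least 8.6-fold lower number from compound 1 to compound 2 (0.93 log units; beyond the scatter), which rests on (the limit of > 20000 nM in this assay, at which 1 of the 3 values shown sits). Compound 3 differs from compound 1 by furan-2-yl in place of iodo on an aromatic carbon, giving an at least 32-fold lower number from compound 1 to compound 3 (1.50 log units; beyond the scatter). Compound 3 stands lowest of the two numbers measured.

Compound 4 `COc1ncnc2c1c(-c1ccco1)cn2[C@@H]1O[C@H](CO)[C@@H](O)[C@H]1O` is not yet measured. It differs from compound 3 by methoxy in place of methylamino on an aromatic carbon, the same change as between compound 1 and compound 2. A step of similar direction is expected, a 6.2-fold lower number from compound 3 to compound 4 (0.79 log units; beyond the scatter), with some allowance because the step from compound 1 rests on a limit. Compound 4 is therefore estimated at 100 nM, within 25 nM to 400 nM.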

Compound 4, half-maximal inhibitory concentration: 100 nM
For compound 4 middle estimate and measured number coincide at the digits printed, within the range that was stated.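

In this assay, methoxy in place of methylamino again lowers the number when furan-2-yl is present, with a 6.2-fold lower number from compound 3 to compound 4 (0.79 log units; beyond the scatter), so the direction carries over from one core to the other, while any difference in size stays unresolved: the same change on two cores in this assay, an at least 8.6-fold lower number (0.93 log units; beyond the scatter) from compound 1 to compound 2 and a 6.2-fold lower number (0.79 log units; beyond the scatter) from compound 3 to compound 4; the limit leaves it open whether they differ
Furan-2-yl in place of iodo likewise keeps its direction on the methoxy core, with a 23-fold lower number from compound 2 to compound 4 (1.36 log units; beyond the scatter), and the comparison of size is equally unresolved: the same change on two cores in this assay, an at least 32-fold lower number (1.50 log units; beyond the scatter) from compound 1 to compound 3 and a 23-fold lower number (1.36 log units; beyond the scatter) from compound 2 to compound 4; the limit leaves it open whether they differ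
The value of compound 1 is a limit, so both comparisons show a shared direction and not a shared size: the limit of > 20000 nM in this assay, at which 1 of the 4 values shown sits.

The compounds shown leave open whether a longer chain such as ethoxy in place of methoxy would follow the same direction. They also leave open whether phenyl in place of furan-2-yl would do so.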